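The compounds below may be only part of what the source reports. "The series", "measured", "known", "first", "only" and "open" are said of these compounds alone.

Compound 1 `NCc1ccc(C(=O)OCCc2ccccc2)cc1` and compound 2 `CCCCOC(=O)c1ccc(CN)cc1` share one core and differ only in the ester chain. In an assay on isolated protein for inhibition of serine protease 1 (Homo sapiens) (a lower number here means a stronger inhibitor, a higher number a weaker inhibitor), compound 1 gives 600000000 nM, and compound 2 gives 910000000 nM. Among the measured compounds shown here, the one step between them, a 1.5-fold higher number from compound 1 to compound 2 (0.18 log units; within the scatter), left the reading essentially where it was. For the measured compounds named here, compound 1 therefore holds the lowest of the two numbers so far, though its nearest neighbour, compound 2, sits within the scatter of it, so no order between the two can be claimed.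

Compound 3 `CCOC(=O)c1ccc(CN)cc1` is the next point on the same chain. Set against compound 1, the change is hydrogen in place of phenyl on a saturated chain carbon, two bonds along the chain from an oxygen next to a carbonyl group. Going by the values given here, the only measured step that bears on it is the one from compound 1 to compound 2, where ethyl stood in for phenyl at the same place and the number moved by a 1.5-fold higher number from compound 1 to compound 2 (0.18 log units; within the scatter), within the scatter. Removing the phenyl altogether, leaving hydrogen, is a change of the same kind but reaching further, so the expected movement in this assay is small and, if anything, toward a higher number. On that basis compound 3 is estimated to come out at 1000000000 nM, with a range from 400000000 nM to 2500000000 nM, a step of a 1.7-fold higher number from compound 1 to compound 3 (0.22 log units; within the scatter) that is expected to stay close to the scatter.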

Compound 3, inhibition constant: 357000000 nM
Estimate against measurement, compound 3: 2.8-fold (0.45 log units) above; the whole stated range lies above it.
By their numbers in this assay, from the lowest: compounds 3, 1 and 2 (each within the scatter of the next, the first and the last beyond it).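

Replacing the phenyl with hydrogen on the saturated chain carbon, two bonds along the chain from an oxygen next to a carbonyl group, gives a 1.7-fold lower number from compound 1 to compound 3 (0.23 log units; within the scatter), so in this assay even complete removal of the phenyl produces no readable change. The step with ethyl at the same place gives the first difference beyond the scatter among these compounds, a 2.5-fold lower number from compound 2 to compound 3 (0.41 log units; beyond the scatter), though it is only modest and compound 1 lies within the scatter of both compound 2 and compound 3, so the three compounds do not form a clear series ordered by the group at this place. No measurement is available that accounts for this small difference.

All three compounds keep the same core and the ester, so the compounds shown leave open whether the number would respond more strongly to a larger change, such as a carboxylic acid or an amide in place of the ester. They also leave open whether a group at this place other than hydrogen, ethyl or phenyl, such as a hydroxyl or an amine, would move the number beyond the modest step seen here.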